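This account rests on a few compounds, and the source may have more. Where it says the series, first, only, none or still open, it means among the compounds named here.

Measured so far:
- Compound 1, `CC1(C2CCCC2)Cc2cc(OCCCc3nn[nH]n3)c(Cl)c(Cl)c2C1=O`: 5000 nM
- Compound 2, `CCCC1Cc2cc(OCc3ccc(-c4nn[nH]n4)cc3)c(Cl)c(Cl)c2C1=O`: 282 nM

Both compounds were tested in an assay on isolated protein for binding affinity to metabotropic glutamate receptor 2 (Homo sapiens); a lower number here means that less compound is needed, a higher number that more compound is needed for the effect. Compound 1 stands at the highest of the two numbers; compound 2 sits at a lower number, and the gap between them is beyond the usual scatter of repeated measurements. The two compounds differ in more than one place, so no single structural step can be read from this pair alone.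

Compound 3, `CC1(C2CCCC2)Cc2cc(OCc3ccc(C(=O)O)cc3)c(Cl)c(Cl)c2C1=O`, has not been measured. It keeps the core of compound 1 and changes one thing: 4-carboxyphenyl in place of 2-(2H-tetrazol-5-yl)ethyl on a saturated chain carbon bound to an oxygen on an aromatic ring. This brings compound 3 closer to the ether pattern of compound 2, a benzyl group carrying an acidic group on its aromatic ring, while the rest of compound 1 is kept.

Among the compounds with values here, with no directly comparable step available, the expectation rests on the lower number of compound 2. The step from compound 1 to compound 3 in this assay is expected to be a clear drop, a 7.1-fold lower number from compound 1 to compound 3 (0.85 log units; beyond the scatter), beyond the scatter. Compound 3 is therefore estimated at 700 nM, within a range from 150 nM to 3000 nM.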

Compound 3, half-maximal effective concentration: 892 nM
For compound 3 the middle estimate is 1.3-fold (0.11 log units) below the measured one, and the stated range covers the measured number.
By their numbers in this assay, from the lowest: compound 2; then compound 3; then compound 1.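

In this assay, putting 4-carboxyphenyl in place of 2-(2H-tetrazol-5-yl)ethyl on a saturated chain carbon bound to an oxygen on an aromatic ring gives a 5.6-fold lower number from compound 1 to compound 3 (0.75 log units; beyond the scatter) on the core of compound 1. Within the data shown here, this is the first step here that can be read as a single change, and it shows that the number responds to what is attached at this place. No measurement here explains the drop, so it cannot be tied to any feature of either group.

The step replaces the whole group, exchanging one ring and its attachment for another, so the compounds shown do not separate the contribution of the six-membered ring from that of the carboxylic acid. On these data alone, whether a plain phenyl group or a primary amide at that end would give a similar number remains open.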